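From Sulfanyl to Sulfonyl: Compound 4 Against Compound 1

The compounds below may be only part of what the source reports. "The series", "measured", "known", "first", "only" and "open" are said of these compounds alone.

In a functional assay on DU-145 cells (Homo sapiens) for inhibition, read by trypan blue exclusion, with a stated time of 96 h (a lower number here means a stronger inhibitor of growth, a higher number a weaker inhibitor of growth), compound 1 `Cc1ccc(CS/C(=C/c2ccc(N(C)C)cc2)C(=O)c2ccc(Cl)cc2)cc1` gives > 100000 nM, which is a limit of the assay and not a number. Its position is described by the limit of > 100000 nM in this assay, at which 1 of the 3 values shown sits. Two compounds measured beside it differ at the aryl group on the double-bonded chain carbon: compound 2 `Cc1ccc(CS/C(=C/c2ccccc2Br)C(=O)c2ccc(Cl)cc2)cc1` gives 10000 nM in this assay, and compound 3 `Cc1ccc(CS/C(=C/c2ccc(O)cc2)C(=O)c2ccc(Cl)cc2)cc1` gives 10000 nM. Those steps, an at least 10-fold lower number from compound 1 to compound 2 (1.00 log units; beyond the scatter) and an at least 10-fold lower number from compound 1 to compound 3 (1.00 log units; beyond the scatter), are the only ones known, and between them no change at the digits printed from compound 2 to compound 3 (within the scatter). Compound 4 `CN(C)c1ccc(/C=C(\C(=O)c2ccc(Cl)cc2)S(=O)(=O)c2ccc(Br)cc2)cc1` differs from compound 1 in another part of the core of compound 1: (4-bromophenyl)sulfonyl in place of (4-methylbenzyl)sulfanyl on a double-bonded chain carbon bound to a carbonyl carbon and a double-bonded chain carbon. For the measured compounds named here, no measured step touches this part, so the known steps give no direction for it, and the limit of compound 1 leaves open how far from that limit compound 4 may fall. Compound 4 is expected to remain a weak inhibitor of growth, at an estimated 30000 nM with a range of 5000 nM to 200000 nM. That expectation corresponds to an at least 3.3-fold lower number from compound 1 to compound 4 (0.52 log units; beyond the scatter).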

Compound 4, concentration for 50% growth inhibition: > 100000 nM
Compound 4 gave a limit, no number; the forecaster's own chance of this, stated with the estimate: 40%; middle value at least 3.3-fold (0.52 log units) away from the limit.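

Compound 1 and compound 4 each give only a limit of the assay, not a number, in this assay, so the step between them cannot be read: the limit of > 100000 nM in this assay, at which 2 of the 4 values shown sit. The compounds shown leave open whether (4-bromophenyl)sulfonyl in place of (4-methylbenzyl)sulfanyl shifts growth inhibition in either direction.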